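Working notes on a five-membered ring swap in the series

A few compounds are considered here, and "the series" means these few. Any claim that something is new, unique, unknown or untested is made for them only; others in the source may bear on it.

Measured so far:
- compound 1 `CC(C)[C@@H](C[C@H]1SC(=O)NC1=O)c1ccc(-c2ccc3cccc(F)c3c2)[nH]c1=O`: in a functional assay on CHO cells for antagonist activity at prostaglandin E2 receptor EP3 subtype (Homo sapiens), read by cAMP accumulation, with a stated time of 30 min (on this read-out lower numbers stand for stronger inhibition and higher numbers for weaker inhibition), compound 1 gives 17 nM
- compound 2 `C/C(=C1/OC(=O)NC1=O)C(c1ccc(-c2ccc3cccc(F)c3c2)[nH]c1=O)C(C)C`: in this assay compound 2 gives 39 nM

Compound 2 stands at the higher of the two numbers recorded in this assay; compound 1 sits lower by a margin beyond the usual scatter, so compound 2 is the weaker of the two on this read-out.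

Compound 3 `CC(C)C(CC1NC(=O)NC1=O)c1ccc(-c2ccc3cccc(F)c3c2)[nH]c1=O` is not yet measured. It differs from compound 2 in one place: a group of 8 heavy atoms (4 carbon, 2 nitrogen, 2 oxygen; one five-membered non-aromatic ring with 2 hetero atoms) in place of a group of 9 heavy atoms (5 carbon, 1 nitrogen, 3 oxygen; one five-membered non-aromatic ring with 2 hetero atoms), on a saturated chain carbon bound to an aromatic carbon and a saturated chain carbon. The saturated linkage between the shared core and the five-membered ring in compound 3 is of the same kind as in compound 1, whereas compound 2 carries a double bond there.

Among the compounds with values here, no step between measured compounds isolates this change, so the expectation rests on the two numbers alone. Compound 3 is expected to land between the two measured values, an estimated step of a 1.4-fold lower number from compound 2 to compound 3 (0.14 log units; within the scatter) toward stronger inhibition, modest and close to the edge of the scatter. For compound 3 in this assay the estimate is 28 nM, within a range of 8 nM to 110 nM.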

Compound 3, half-maximal inhibitory concentration: 31 nM
Estimate against measurement, compound 3: 1.1-fold (0.04 log units) below; the range from low to high includes it.
By their numbers in this assay, from the lowest: compounds 1, 3 and 2 (each within the scatter of the next, the first and the last beyond it).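

In this assay, placing (2,5-dioxoimidazolidin-4-yl)methyl on the saturated chain carbon bound to an aromatic carbon and a saturated chain carbon gives a 1.3-fold lower number from compound 2 to compound 3 (0.10 log units; within the scatter), so at this position the change cannot be told from repeat variation on this read-out. The entering group has 8 heavy atoms, 2 hydrogen-bond donors and 2 hydrogen-bond acceptors, against 9, 1 and 3 in the group that leaves, and these differences in composition come with no step beyond the scatter here; compound 3 also stands within the scatter of compound 1, even though compound 1 and compound 2 are separated by more than the scatter. No measurement is available that bears on the origin of this result.

The compounds shown leave open whether a carboxylic acid or an open-chain urea on the same chain carbon would hold the number in this assay, and so whether a five-membered ring is needed there at all. Also open, going by these compounds, is the role of configuration, since compound 1 is drawn with defined stereocentres and compound 3 without them.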